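This account rests on a few compounds, and the source may have more. Where it says the series, first, only, none or still open, it means among the compounds named here.

Measured in a functional assay on MDA-MB-231 cells (Homo sapiens) for antiproliferative activity, with a stated time of 4 days; a higher number here means a weaker inhibitor, a lower number a stronger inhibitor:
- compound 1 `CCCCc1ccc2[nH]c(-c3ccc(OC)cc3)c(C=O)c2c1`: 6.7 nM
- compound 2 `CCCCc1ccc2[nH]c(-c3ccc(OC)cc3)c(/C=N\C)c2c1`: 6 nM

Compound 2 stands level with compound 1 in this assay, the two values lying within the scatter of each other. Compound 3 `CCCCc1ccc2[nH]c(-c3ccc(OC)cc3)c(/C=N\O)c2c1` has hydroxy in place of methyl on a double-bonded nitrogen. Within the data shown here, only one measured step bears on this change: a 1.1-fold lower number from compound 1 to compound 2 (0.05 log units; within the scatter). Among the measured compounds shown here, it altered the same group on the shared core, but no measured step covers this exchange directly, so the range stays wide. No step beyond the scatter is expected in this assay. The estimated step is a 1.7-fold higher number from compound 2 to compound 3 (0.22 log units; within the scatter). Compound 3 is expected at 10 nM, with an estimated range of 3 nM to 50 nM.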

Compound 3, half-maximal inhibitory concentration: 40 nM
For compound 3 the middle estimate is 4.0-fold (0.60 log units) below the measured one; the range from low to high includes it.
By their numbers in this assay, from the lowest: compounds 2 and 1 (each within the scatter of the next); then compound 3.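

In this assay, among these compounds, the group on this nitrogen matters: hydroxy in place of methyl on a double-bonded nitrogen gives a 6.7-fold higher number from compound 2 to compound 3 (0.82 log units; beyond the scatter), the first step beyond the scatter. The carbonyl-bearing group of the shared core gives way to the hydroxy-bearing one with a similar loss, a 6.0-fold higher number from compound 1 to compound 3 (0.78 log units; beyond the scatter), so tolerance at this position does not extend to every small group. Nothing measured here accounts for this difference. On these data alone, whether methoxy or ethyl on the double-bonded nitrogen would stay level with methyl or fall towards hydroxy remains open.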